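Replacing the 3-methoxyazetidin-1-yl group of compound 2

The compounds below may be only part of what the source reports. "The series", "measured", "known", "first", "only" and "open" are said of these compounds alone.

compound 1 `COc1ncc(-c2cc3c(N4CCCCC4)ncnc3s2)cc1NS(=O)(=O)c1ccc(F)cc1F`: 1200 nM
compound 2 `COc1ncc(-c2cc3c(N4CC(OC)C4)ncnc3s2)cc1NS(=O)(=O)c1ccc(F)cc1F`: 830 nM

In a functional assay on HGC-27 cells (Homo sapiens) for antiproliferative activity, read by MTT assay, with stated times of 72 h and 4 h (a lower number here means a stronger inhibitor, a higher number a weaker inhibitor), compound 2 gives 830 nM, which lies within the scatter of compound 1, so the two cannot be told apart. The next compound is compound 3 `COc1ncc(-c2cc3c(N4CCN(C)C(=O)C4)ncnc3s2)cc1NS(=O)(=O)c1ccc(F)cc1F`, which carries 4-methyl-3-oxopiperazin-1-yl in place of 3-methoxyazetidin-1-yl on an aromatic carbon. Among the compounds with values here, only one measured step bears on this change, a 1.4-fold lower number from compound 1 to compound 2 (0.16 log units; within the scatter), and one step is thin evidence. No shift beyond the scatter is therefore expected, and no direction can be favoured. The estimate is a 1.2-fold higher number from compound 2 to compound 3 (0.08 log units; within the scatter). For compound 3 the expected value is 1000 nM, with an estimated range of 350 nM to 3000 nM.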

Compound 3, half-maximal inhibitory concentration: 920 nM
Compound 3: middle estimate off by 1.1-fold (0.04 log units), on the high side; low and high end bracket the measured number.
By their numbers in this assay, from the lowest: compounds 2, 3 and 1 (each within the scatter of the next).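

In this assay, 4-methyl-3-oxopiperazin-1-yl gives a 1.1-fold higher number from compound 2 to compound 3 (0.04 log units; within the scatter) and a 1.3-fold lower number from compound 1 to compound 3 (0.12 log units; within the scatter), so compound 3 cannot be told apart from either earlier compound. On this aromatic carbon, the three non-aromatic rings, including one with a carbonyl, therefore show no difference beyond the scatter. No measurement given here accounts for this result.

On these data alone, all three groups are non-aromatic rings, so it remains open whether an open chain such as dimethylamino, or a carboxylic acid, would move the number beyond the scatter.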